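The source may report more compounds than this note shows. Statements on the series, on what has been measured and on what is new or still open speak of the compounds shown alone.

Two compounds carrying the same shared core were measured in a functional assay on HCT-116 cells (Homo sapiens) for inhibition, read by CCK-8 assay, with a stated time of 48 h; a higher number here means a weaker inhibitor, a lower number a stronger inhibitor. Compound 1 `COc1ccc(-c2cc3nccc(-c4cc(OC)c(OC)c(OC)c4)n3n2)cc1[N+](=O)[O-]` reaches only the limit of this assay, giving > 10000 nM. Compound 2 `COc1cc(-c2ccnc3cc(-c4c[nH]c5ccccc45)nn23)cc(OC)c1OC` gives 35 nM. Among the compounds with values here, that value of compound 2 is the only plain number among the values shown. The other value, that of compound 1, is a limit (the limit of > 10000 nM in this assay, at which 1 of the 2 values shown sits). Compound 3 `COc1cc(-c2ccnc3cc(-c4ccc(F)cc4)nn23)cc(OC)c1OC` has not yet been measured. It differs from compound 2 in one place (4-fluorophenyl in place of 1H-indol-3-yl on an aromatic carbon). Within the data shown here, no step between two measured compounds that differ in one place is available to guide the expectation, so the direction of the change has to be estimated from the structural change alone. The account expects the step from compound 2 to compound 3 in this assay to be an 8.6-fold higher number from compound 2 to compound 3 (0.93 log units; beyond the scatter), a moderate loss that goes beyond the usual scatter. For compound 3 the estimated value in this assay is 300 nM, with a range from 60 nM to 1500 nM.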

Compound 3, half-maximal inhibitory concentration: 5030 nM
The estimate for compound 3 lay 17-fold (1.22 log units) below the measured number, and the stated range ends below it.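

In this assay, within the data shown here, putting 4-fluorophenyl in place of 1H-indol-3-yl on this aromatic carbon gives a 140-fold higher number from compound 2 to compound 3 (2.16 log units; beyond the scatter), the first step that can be read at this position. It shows that the number depends strongly on the group carried here, even though the trimethoxyphenyl side and the rest of the shared core stay the same. Nothing measured among the compounds shown bears on the cause of this step.

The compounds shown leave open whether the loss follows from the hydrogen-bond donor of 1H-indol-3-yl or from its five-membered aromatic ring, and a 1-methylindol-3-yl or a 2-naphthyl group would separate these two. Going by these compounds, whether the fluorine plays any part also stays open, and an unsubstituted phenyl would address that.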